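Dropping One Hydroxy from Compound 1

The source may hold more compounds than are shown below. What is called first, only, known or untested is meant among the compounds shown, and "the series" means these compounds.

Measured so far:
compound 1 `Oc1cc(O)c(/C=N/c2ccc(OCc3ccccc3)cc2)c(O)c1` — 23900 nM
compound 2 `O=[N+]([O-])c1ccc(O)c(/C=N/c2ccc(OCc3ccccc3)cc2)c1` — > 200000 nM

In a functional assay, with a stated time of 30 min (a lower number here means a stronger inhibitor, a higher number a weaker inhibitor), compound 1 gives 23900 nM. This is the only real number among the two results shown. For compound 2 this assay reports only a limit, > 200000 nM, and not a number; of the two values, one sits at this limit (the limit of > 200000 nM in this assay, at which 1 of the 2 values shown sits). Compound 2 differs from compound 1 in more than one place, so the pair does not amount to a single step. Its two values show no more than that compound 1 gives a number while compound 2 does not.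

Compound 3 `Oc1ccc(/C=N/c2ccc(OCc3ccccc3)cc2)c(O)c1` is the next compound to be measured. It differs from compound 1 in one way: hydrogen in place of hydroxy on an aromatic carbon. For the measured compounds named here, no step between measured compounds is available to guide the size of this change. Removing a hydroxy is expected to weaken the inhibitor somewhat, a step of a 2.1-fold higher number from compound 1 to compound 3 (0.32 log units; beyond the scatter) in this assay, with a real chance that only a limit is reported. Compound 3 is therefore estimated at 50000 nM, within a range from 15000 nM to 200000 nM.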

Compound 3, half-maximal inhibitory concentration: > 200000 nM
Compound 3: no number, only a limit; the forecaster's own chance of this, stated with the estimate: 25%; middle value at least 4.0-fold (0.60 log units) from the limit.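

Replacing the hydroxy that sits ortho to a large group with hydrogen gives an at least 8.3-fold higher number from compound 1 to compound 3 (0.92 log units; beyond the scatter) in this assay. For the compounds shown here, this is the first change in one place that can be read here, and it shows that this single hydroxy counts for a great deal: compound 1 keeps a measurable value with it, while the version with hydrogen does not. The value of compound 3 is a limit and not a number, so the step gives only a minimum size, and compound 1 is now the only compound shown with a real number: the limit of > 200000 nM in this assay, at which 2 of the 3 values shown sit.

The compounds shown leave open how large the loss really is and why it occurs, and they do not show whether the two remaining hydroxy groups matter as much as this one. They also leave open whether the hydroxy itself is required at this position or whether another group, such as a methoxy, an amine or a fluorine atom, could take its place and still give a number.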